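Compound 2 to compound 4: a step from a limit

A few compounds are considered here, and "the series" means these few. Any claim that something is new, unique, unknown or untested is made for them only; others in the source may bear on it.

In a physicochemical assay for solubility, using the shake flask method, in simulated intestinal fluid, measured as kinetic solubility, with a stated time of 2 h, at 25 degrees C, at pH 6.5 (on this read-out higher numbers stand for higher solubility and lower numbers for lower solubility), compound 2, `CCCOC(=O)c1nc(C)c2c(c1N)C(=O)N(Cc1ccccc1)C2=O`, gives < 5000 nM, which is a limit and not a number. Compound 1, `Cc1nc(C#N)c(N)c2c1C(=O)N(Cc1ccccc1)C2=O`, gives < 5000 nM, also a limit. Compound 3, `Cc1noc(-c2nc(C)c3c(c2N)C(=O)N(Cc2ccccc2)C3=O)n1`, gives < 5000 nM, again a limit. The three therefore share a single limit: the limit of < 5000 nM in this assay, at which 3 of the 3 values shown sit.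

Compound 4, `Cc1nc(C(=O)NC#N)c(N)c2c1C(=O)N(Cc1ccccc1)C2=O`, carries cyanoamino in place of propoxy on a carbonyl carbon, so that propoxycarbonyl becomes cyanocarbamoyl: cyanoamino in place of propoxy on a carbonyl carbon.

Among the compounds with values here, three measured steps bear on this site: a step that the two limits leave unreadable from compound 1 to compound 2, a step that the two limits leave unreadable from compound 1 to compound 3 and a step that the two limits leave unreadable from compound 2 to compound 3. None of them has a readable size, so the series offers no measured size to carry over to the new group.

The expected change is therefore a loose estimate, weakly favouring an upward direction: an at least 1.6-fold higher number from compound 2 to compound 4 (0.20 log units; that floor lies within the scatter). Another reported limit remains quite possible.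

For compound 4 the estimated value in this assay is 8000 nM, with an expected range of 1500 nM to 60000 nM.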

Compound 4, solubility: 185000 nM
Compound 4: middle estimate off by 23-fold (1.36 log units), on the low side, outside the stated range (above it).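

In this assay, within the data shown here, cyanoamino in place of propoxy on a carbonyl carbon gives an at least 37-fold higher number from compound 2 to compound 4 (1.56 log units; beyond the scatter), the first readable step at this position. Cyanocarbamoyl in place of 3-methyl-1,2,4-oxadiazol-5-yl on an aromatic carbon gives an at least 37-fold higher number from compound 3 to compound 4 (1.56 log units; beyond the scatter), and cyanocarbamoyl in place of cyano on an aromatic carbon gives an at least 37-fold higher number from compound 1 to compound 4 (1.56 log units; beyond the scatter), so all three steps to compound 4 are large and only their floors are known. The steps among compound 1, compound 2 and compound 3 cannot be read, and those three stay unresolved against one another: the limit of < 5000 nM in this assay, at which 3 of the 4 values shown sit.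

Going by these compounds, how far compound 1, compound 2 and compound 3 actually lie under their shared limit stays open, and with it the full size of each step to compound 4. Also open, on these data alone, is whether an amine or a hydroxyl on the same carbonyl carbon would behave like cyanoamino, which would show whether the nitrile of the new group is needed for the rise.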